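The source may report more compounds than this note shows. Statements on the series, on what has been measured and on what is new or still open speak of the compounds shown alone.

Compound 1 `Cc1ccc(S(=O)(=O)N2C=CNC(=O)[C@H]2CC(=O)N[C@@H]2CCCc3cc(CN(C)C)ccc32)cc1`: 0.21 nM
Compound 2 `Cc1ccc(S(=O)(=O)N2C=CNC(=O)[C@H]2CC(=O)NC2CCNc3ccccc32)cc1`: 21.6 nM
Compound 3 `CC(=O)N1CCC(NC(=O)C[C@@H]2C(=O)NC=CN2S(=O)(=O)c2ccc(C)cc2)c2ccccc21`: 72.2 nM

In an in vitro functional assay on cells for antagonist activity at B1 bradykinin receptor (Homo sapiens), read by luminescence and calcium flux, with a stated time of 2 h (on this read-out higher numbers stand for weaker inhibition and lower numbers for stronger inhibition), compound 2 gives 21.6 nM, the second highest of the three numbers; compound 3 lies a 3.3-fold higher number from compound 2 to compound 3 (0.52 log units; beyond the scatter) away, while compound 1 sits far lower at 0.21 nM. Compound 4 `Cc1ccc(S(=O)(=O)N2C=CNC(=O)[C@H]2CC(=O)NC2CCOCC2(C)C)cc1` differs from compound 2 by a group of 8 heavy atoms (7 carbon, 1 oxygen; one six-membered non-aromatic ring with 1 hetero atom) in place of a group of 10 heavy atoms (9 carbon, 1 nitrogen; one six-membered non-aromatic ring with 1 hetero atom, one six-membered aromatic ring of carbon only), on an amide-type nitrogen. Within the data shown here, none of the measured steps covers this change directly: the only single-point step, from compound 2 to compound 3, concerns an acetyl in place of hydrogen on a nitrogen on an aromatic ring in a ring and gave a 3.3-fold higher number from compound 2 to compound 3 (0.52 log units; beyond the scatter), and the gap between compound 2 and compound 1 involves several changes at once. Among the measured compounds shown here, the change to compound 4 removes the six-membered aromatic ring of carbon only that compound 1, compound 2 and compound 3 all carry, so the expected step is a weakening, a 14-fold higher number from compound 2 to compound 4 (1.14 log units; beyond the scatter), larger than the step from compound 2 to compound 3. For compound 4 the estimate in this assay is 300 nM, with a range from 50 nM to 3000 nM.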

Compound 4, half-maximal inhibitory concentration: 25.2 nM
The estimate for compound 4 lay 12-fold (1.08 log units) above the measured number; the whole stated range lies above it.
By their numbers in this assay, from the lowest: compound 1; then compounds 2 and 4 (each within the scatter of the next); then compound 3.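

In this assay the step at this amide-type nitrogen is a 1.2-fold higher number from compound 2 to compound 4 (0.07 log units; within the scatter), which shows that the group of 8 heavy atoms, with one six-membered non-aromatic ring holding 1 hetero atom, can stand in place of the group of 10 heavy atoms with no difference beyond the scatter. Compounds 1, 2 and 3 all carry the six-membered aromatic ring of carbon only, so they could not show that a number of this size holds without it. No measured evidence bears on why this is so.

The compounds shown leave open how the non-aromatic ring of compound 4 would read with an amine or a carboxylic acid attached. Among these compounds, they also leave open what the oxygen in that ring contributes, as no compound here has a different atom in its place.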